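Adding a Third Methoxy Group on the Ketone Side

A few compounds are considered here, and "the series" means these few. Any claim that something is new, unique, unknown or untested is made for them only; others in the source may bear on it.

Of the compounds shown here, three sharing one core have been measured in a functional assay on SK-OV-3 cells (Homo sapiens) for inhibition, read by sulforhodamine B assay, with a stated time of 48 h; a higher number here means that more compound is tolerated, a lower number that less compound is tolerated. Compound 1 `COc1cc(-c2cc(/C=C/C(=O)c3ccc(Cl)c(Cl)c3)[nH]n2)cc(OC)c1OC` gives 62500 nM in this assay. Compound 2 `COc1ccc(C(=O)/C=C/c2cc(-c3cc(OC)c(OC)c(OC)c3)n[nH]2)cc1OC` gives 27600 nM, the lowest of the two numbers recorded, the step of a 2.3-fold lower number from compound 1 to compound 2 (0.35 log units; beyond the scatter) being beyond the scatter. Compound 3 `COc1cc(-c2cc(/C=C/C(=O)c3ccc(F)c(F)c3)[nH]n2)cc(OC)c1OC` reaches only a limit of the assay, > 100000 nM, so no number is known for it; the step of an at least 3.6-fold higher number from compound 2 to compound 3 (0.55 log units; beyond the scatter) describes what can be said, and the limit of > 100000 nM in this assay, at which 1 of the 3 values shown sits, marks this floor.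

Compound 4 `COc1cc(C(=O)/C=C/c2cc(-c3cc(OC)c(OC)c(OC)c3)n[nH]2)cc(OC)c1OC` differs from compound 2 in one place: methoxy in place of hydrogen on an aromatic carbon, the new group entering on an aromatic carbon of a six-membered aromatic ring of carbon only, so that the ring on the carbonyl carbon now carries three methoxy groups.

For the measured compounds named here, no measured step adds a single methoxy group. Going by the values given here, the steps that bear on the ring on the carbonyl carbon exchange whole pairs of substituents: a 2.3-fold lower number from compound 1 to compound 2 (0.35 log units; beyond the scatter) favours methoxy over chlorine, and an at least 3.6-fold higher number from compound 2 to compound 3 (0.55 log units; beyond the scatter) favours methoxy over fluorine, both of modest size. A further methoxy group is therefore expected to move the number little, and compound 4 is estimated at 20000 nM, between 8000 nM and 60000 nM, corresponding to an expected step of a 1.4-fold lower number from compound 2 to compound 4 (0.14 log units; within the scatter), a change that may not exceed the scatter.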

Compound 4, concentration lethal to 50% of the cells: 33400 nM
Estimate against measurement, compound 4: 1.7-fold (0.22 log units) below; the measured number falls inside the stated range.
By their numbers in this assay, from the lowest: compounds 2, 4 and 1 (each within the scatter of the next, the first and the last beyond it). At a limit, above all of these: compound 3.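

In this assay the step of a 1.2-fold higher number from compound 2 to compound 4 (0.08 log units; within the scatter) is the first shown to change a single group, and it shows that a methoxy group can take the place of hydrogen at this position, ortho to a methoxy group and meta to a large group, while compound 2 and compound 4 cannot be told apart. The earlier steps shown here exchanged whole pairs of substituents on the ring on the carbonyl carbon, so they could not show what one added group does on its own. Here, a ring carrying three methoxy groups reads the same, within the scatter, as one carrying two, and nothing shown gives a measured reason for this result.

Still open, on these data alone, is whether a different group on this aromatic carbon, such as an amine, a carboxylic acid or a longer chain, would move the number beyond the scatter. Also open, as far as these compounds go, is whether the same added methoxy group would read alike on the ring on the carbonyl carbon of compound 1, where chlorine stands in place of the two methoxy groups of compound 2.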